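A Methyl Added to the Core of Compound 1

The source may report more compounds than this note shows. Statements on the series, on what has been measured and on what is new or still open speak of the compounds shown alone.

Compound 1 `N/C(=N\NC(=S)N1CCCCCC1)c1ccccn1`: 78.6%
Compound 2 `N/C(=N\NC(=S)N1CCN(c2ccccn2)CC1)c1ccc(F)cn1`: 53.1%
Compound 3 `Cc1cccc(/C(N)=N/NC(=S)N2CCOCC2)n1`: 34.7%

In a functional assay on A-375 cells (Homo sapiens) for cytotoxicity, read by MTT assay, with a stated time of 72 h, tested at 3 uM (a higher number here means more inhibition of growth at the concentration tested, a lower number less inhibition of growth), compound 1 gives 78.6%, the highest of the three numbers. Compound 2 gives 53.1%, which lies below it beyond the scatter. Compound 3 gives 34.7%, the furthest below, also beyond the scatter. Going by the values given here, compound 4 `Cc1ccnc(/C(N)=N/NC(=S)N2CCCCCC2)c1` differs from compound 1 only by methyl in place of hydrogen on an aromatic carbon, a change that no pair among the measured compounds isolates on its own. The step of a number 8.6 percentage points lower from compound 1 to compound 4 (within the scatter) is expected to be small, most likely a slight loss of growth inhibition that may not exceed the scatter. Compound 4 is therefore expected to give about 70%, with a range from 50% to 85%.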

Compound 4, percent growth inhibition at one concentration: 70%
Estimate against measurement, compound 4: no gap at the digits printed, within the range that was stated.
By their numbers in this assay, from the lowest: compound 3; then compound 2; then compounds 4 and 1 (each within the scatter of the next).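

In this assay, the step for methyl in place of hydrogen on an aromatic carbon, opposite the ring nitrogen, is a number 8.6 percentage points lower from compound 1 to compound 4 (within the scatter). This is the first pair among the compounds shown that isolates this change, and it shows that the position accepts methyl with no difference from hydrogen that can be told from the scatter. Nothing measured here bears on why the step has this size. Going by these compounds, whether a methoxy group, an amine or a longer chain would be accepted at this position stays open. So does the effect of fluorine there.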